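Amide variation at the carbonyl of the shared core

This account rests on a few compounds, and the source may have more. Where it says the series, first, only, none or still open, it means among the compounds named here.

Three analogues of the shared core have been measured in an ADME assay on MRC5 cells (Homo sapiens) for inhibition, with a stated time of 72 h; a higher number here means that more compound is needed for the effect, a lower number that less compound is needed. Compound 1 `COc1cccc(OC)c1C(=O)Nc1c[nH]nc1C(=O)NC1CC1` returns a limit of the assay, > 50000 nM. Compound 2 `COCCNC(=O)c1n[nH]cc1NC(=O)c1c(OC)cccc1OC` also returns a limit, > 50000 nM. Compound 3 `COC(=O)c1n[nH]cc1NC(=O)c1c(OC)cccc1OC` likewise sits at a limit, > 50000 nM. Compound 3 therefore stands nowhere distinguishable on the numbers shown: all three values sit at the same limit (the limit of > 50000 nM in this assay, at which 3 of the 3 values shown sit).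

Compound 4 `COc1cccc(OC)c1C(=O)Nc1c[nH]nc1C(=O)Nc1ccccn1` differs from compound 3 by (pyridin-2-yl)amino in place of methoxy on a carbonyl carbon. The measured steps that bear on this change are a step that the two limits leave unreadable from compound 1 to compound 3 and a step that the two limits leave unreadable from compound 2 to compound 3, both on the same carbonyl carbon, and the further step that the two limits leave unreadable from compound 1 to compound 2; none of them has a readable size or direction because every value involved sits at the limit (the limit of > 50000 nM in this assay, at which 3 of the 3 values shown sit). Within the data shown here, no measured step thus gives a size for the change in this assay. Expected is a number no higher from compound 3 to compound 4 (the limit leaves the size open), a step not beyond the scatter. Compound 4 is estimated at 50000 nM, within 20000 nM to 200000 nM, and is expected most likely to be reported only as a limit again.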

Compound 4, half-maximal effective concentration: > 50000 nM
Compound 4: a limit, no number (the forecaster's own chance of this, stated with the estimate: 80%); the middle value sits exactly at the limit.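

No step from compound 4 to compound 1, compound 2 or compound 3 can be read in this assay, and none of the earlier steps can either: the limit of > 50000 nM in this assay, at which 4 of the 4 values shown sit.

The compounds shown leave open whether any of these groups on the carbonyl carbon changes the half-maximal effective concentration in this assay at all.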